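Imidazole in place of hydroxy: cytotoxicity outlook

The source may hold more compounds than are shown below. What is called first, only, known or untested is meant among the compounds shown, and "the series" means these compounds.

Compound 1 `O=C1O[C@@H](CO)CN1c1ccc(-n2cc(-c3ccccn3)cn2)c(F)c1` gives > 400 ug/mL in an ADME assay on HEK293-A cells (Homo sapiens) for cytotoxicity, read by MTT assay, with a stated time of 48 h (on this read-out lower numbers stand for stronger inhibition and higher numbers for weaker inhibition), which is a limit of the assay rather than a number.
Compound 2 `CN(CCC#N)C[C@H]1CN(c2ccc(-n3cc(-c4ccccn4)cn3)c(F)c2)C(=O)O1` gives > 400 ug/mL in this assay, likewise a limit.
Compound 3 `COC(=O)CC1CCN(C[C@H]2CN(c3ccc(-n4cc(-c5ccccn5)cn4)c(F)c3)C(=O)O2)CC1` gives 224 ug/mL in this assay.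

Compound 1 stands at the limit, and (the limit of > 400 ug/mL in this assay, at which 2 of the 3 values shown sit). Compound 4 `O=C1O[C@@H](Cn2ccnc2)CN1c1ccc(-n2cc(-c3ccccn3)cn2)c(F)c1` differs from compound 1 by 1H-imidazol-1-yl in place of hydroxy on a saturated chain carbon bound to a saturated ring carbon. The measured steps at the same place give little guidance: a step that the two limits leave unreadable from compound 1 to compound 2, and an at least 1.7-fold lower number from compound 1 to compound 3 (0.25 log units; that floor lies within the scatter). The only number shown, that of compound 3, lies close to the limit, and no step beyond the scatter has been seen. Compound 4 is therefore expected to give about 400 ug/mL (range 220 ug/mL to 800 ug/mL), meaning a number no higher from compound 1 to compound 4 (the limit leaves the size open), with a limit the likeliest report.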

Compound 4, half-maximal inhibitory concentration: > 400 ug/mL
Compound 4: no number, only a limit; the forecaster's own chance of this, stated with the estimate: 65%; the middle value sits exactly at the limit.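

Swapping hydroxy for the five-membered aromatic ring of 1H-imidazol-1-yl on this saturated chain carbon leaves compound 4 at a limit, so a ring group directly on this carbon now shares that result with the open-chain group of compound 2: (the limit of > 400 ug/mL in this assay, at which 3 of the 4 values shown sit). an at least 1.7-fold higher number from compound 3 to compound 4 (0.25 log units; that floor lies within the scatter) is the one step that can be read. The steps joining compound 4 to compound 1 and compound 2 cannot be read, with limits at both ends.

As far as these compounds go, only compound 3 gives a number, so how far groups at this place can move the value stays open. A carboxylic acid or a primary amine on this carbon remains untested among the compounds shown.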